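The source may hold more compounds than are shown below. What is called first, only, known or untested is meant among the compounds shown, and "the series" means these compounds.

Compounds measured in a functional assay on Umbilical vein for antagonist activity at B1 bradykinin receptor (Homo sapiens), using Schild analysis, with a stated time of 30 min; a lower number here means a less potent compound, a higher number a more potent compound, by a factor of ten per unit of this negative logarithm:
- compound 1 `COc1cc(C)c(S(=O)(=O)N(C)CCOCC(=O)N2CCN(C3CCN(C4CC4)CC3)CC2)c(C)c1`: 8.5
- compound 2 `COc1cc(C)c(S(=O)(=O)N(C)CCOCC(=O)N2CCC(C(O)CN(C)C)CC2)c(C)c1`: 7.4

Of the two numbers in hand, compound 1 stands highest; its nearest neighbour, compound 2, sits lower by a gap that lies beyond the usual scatter of repeated measurements. Compound 3 `COc1cc(C)c(S(=O)(=O)N(C)CCOCC(=O)N2CCN(CCCN(C)C)CC2)c(C)c1` has not been measured. It differs from compound 1 in one place: 3-(dimethylamino)propyl in place of 1-cyclopropylpiperidin-4-yl on an amine nitrogen in a ring. Among the compounds with values here, no step between two measured compounds with this same change is available, so the size of the step can only be expected, not read from the data. The shared core stays intact, and the group that enters keeps one hydrogen-bond acceptor on a flexible chain where compound 1 carried a ring. Compound 3 is therefore expected to stay near compound 1, with a small loss of a number 0.50 log units lower from compound 1 to compound 3 (beyond the scatter) judged most likely, yet one that may well fall within the scatter. The estimate for compound 3 is 8, with a range from 7.3 to 8.7.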

Compound 3, negative logarithm of the antagonist equilibrium constant: 7.9
Estimate against measurement, compound 3: 0.10 log units above; low and high end bracket the measured number.
By their numbers in this assay, from the lowest: compound 2; then compound 3; then compound 1.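

In this assay, the step at this amine nitrogen in a ring is now measured: 3-(dimethylamino)propyl in place of 1-cyclopropylpiperidin-4-yl gives a number 0.60 log units lower from compound 1 to compound 3 (beyond the scatter), a modest loss that lies beyond the scatter. The position therefore accepts a group with no ring while compound 3 still reads 7.9, and the two groups match in their counts of hydrogen-bond donors and acceptors, so the step comes with a change in ring content and size rather than in those counts. No measurement on these compounds accounts for the step.

Going by these compounds, it remains open which part of the departing group matters, as 1-methylpiperidin-4-yl would separate the piperidine ring from the cyclopropyl. A longer chain such as 4-(dimethylamino)butyl would likewise test how the value follows chain length.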